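Compound 3 to Compound 4: One Ring Substituent Changed

This account rests on a few compounds, and the source may have more. Where it says the series, first, only, none or still open, it means among the compounds named here.

Three compounds have been measured in a functional assay (aorta) with Rattus norvegicus as the target; on this read-out lower numbers stand for stronger inhibition and higher numbers for weaker inhibition:
compound 1 `CC1(C)Oc2ccc(C#N)cc2[C@@H](NC(=O)Nc2ccccc2)[C@@H]1O` gives 800 nM
compound 2 `CCC(C)(C)/N=C(\NC#N)N[C@@H]1c2cc(C#N)ccc2OC(C)(C)[C@H]1O` gives 29800 nM
compound 3 `CC1(C)Oc2ccc(C#N)cc2[C@@H](/N=C(\NC#N)Nc2ccc(C(F)(F)F)cc2)[C@@H]1O` gives 8100 nM

Compound 3 holds the second highest of the three numbers in this assay. Compound 2 lies above it and compound 1 below it, and both of those gaps fall beyond the usual scatter, so compound 3 is clearly separated from each of its neighbours in this set.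

Compound 4 `CC1(C)Oc2ccc(C#N)cc2[C@@H](/N=C(\NC#N)Nc2ccc(Cl)c(F)c2)[C@@H]1O` is not yet measured. It differs from compound 3 in one place: 4-chloro-3-fluorophenyl in place of 4-(trifluoromethyl)phenyl on an amine nitrogen. Going by the values given here, nothing among the measured compounds shows what such an exchange of one substituted phenyl group for another does in this assay; no comparable pair exists here. In the absence of such a guide, the step from compound 3 to compound 4 is expected to be small, and quite possibly to stay within the scatter: a 1.4-fold lower number from compound 3 to compound 4 (0.13 log units; within the scatter). On that basis compound 4 is estimated to give 6000 nM in this assay, with a plausible range from 2000 nM to 20000 nM.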

Compound 4, half-maximal inhibitory concentration: 1660 nM
Compound 4: middle estimate off by 3.6-fold (0.56 log units), on the high side; the measured number lies below the stated range.
By their numbers in this assay, from the lowest: compound 1; then compound 4; then compound 3; then compound 2.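

In this assay, putting 4-chloro-3-fluorophenyl in place of 4-(trifluoromethyl)phenyl on the amine nitrogen gives a 4.9-fold lower number from compound 3 to compound 4 (0.69 log units; beyond the scatter). This shows that the read-out responds to the substituents on this phenyl ring, even though the ring itself stays and both groups count no hydrogen-bond donors or acceptors and no net charge. Nothing shown explains why the number falls.

The exchange alters the ring at more than one place at once, so this single step cannot say whether the chlorine, the fluorine or the loss of trifluoromethyl accounts for the difference. The compounds shown also leave open how 4-chlorophenyl, 3-fluorophenyl or a pyridine ring would read on this same nitrogen.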